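Halogen change on the anilino ring ahead of compound 3

The compounds below may be only part of what the source reports. "The series", "measured", "known", "first", "only" and "open" are said of these compounds alone.

Measured so far:
compound 1 `COc1cc(NC(=O)Nc2cc(Nc3cc(F)ccc3OC)ncn2)cc(OC)c1` gives 38%
compound 2 `COc1cc(NC(=O)Nc2cc(Nc3cc(I)ccc3OC)ncn2)cc(OC)c1` gives 55%

In a functional assay on NCI-H520 cells (Homo sapiens) for inhibition, read by MTT assay, with a stated time of 48 h, tested at 10 uM (a lower number here means less inhibition, a higher number more inhibition at the concentration tested (going by the name of the read-out)), compound 2 stands highest of the two numbers shown; the only step measured, a number 17 percentage points higher from compound 1 to compound 2 (beyond the scatter), was a modest rise beyond the scatter. Compound 3 `COc1cc(NC(=O)Nc2cc(Nc3ccc(Br)cc3OC)ncn2)cc(OC)c1` is not yet measured. It differs from compound 2 by 4-bromo-2-methoxyphenyl in place of 5-iodo-2-methoxyphenyl on a nitrogen on an aromatic ring. Within the data shown here, the single measured step swapped one halogen for another at the same spot, so it bears only loosely on a change that alters both the halogen and its place on the ring. Compound 3 is therefore expected near 46%, within 30% to 62%, the expected step being a number 9 percentage points lower from compound 2 to compound 3 (within the scatter), likely inside the scatter.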

Compound 3, a percentage reported as inhibition, at one concentration (the size of the read-out at that concentration, not a potency): 36.1%
Estimate against measurement, compound 3: 9.9 percentage points above, within the range that was stated.
By their numbers in this assay, from the lowest: compounds 3 and 1 (each within the scatter of the next); then compound 2.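

In this assay the change to 4-bromo-2-methoxyphenyl gives a number 18.9 percentage points lower from compound 2 to compound 3 (beyond the scatter) and so the higher reading of compound 2 does not extend to this bromo group. The change from the fluoro group gives a number 1.9 percentage points lower from compound 1 to compound 3 (within the scatter) and so does not separate 4-bromo-2-methoxyphenyl from 5-fluoro-2-methoxyphenyl at this nitrogen. No available evidence explains the drop from the iodo group.

Open, going by these compounds, is whether the halogen or its place on the ring carries that drop. A 5-bromo-2-methoxyphenyl group on the same nitrogen would bear directly on this.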